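The compounds below may be only part of what the source reports. "The series", "measured", "known", "first", "only" and "open" are said of these compounds alone.

Compound 3 `Cc1ccc2[nH]nc(Nc3cccc(Cl)c3)c2c1` carries a methyl group on the shared core; in an assay for inhibition of acyl-CoA (8-3)-desaturase (Homo sapiens) (a lower number here means a stronger inhibitor, a higher number a weaker inhibitor), compound 3 gives 6 nM. Among the three measured compounds it stands second highest, close to compound 1 `Clc1cccc(Nc2n[nH]c3ccc(Cl)cc23)c1`, which gives 5 nM, and clearly apart from compound 2 `Clc1cccc(Nc2n[nH]c3ccc(Br)cc23)c1`, which gives 21 nM. Compound 4 `COc1ccc2[nH]nc(Nc3cccc(Cl)c3)c2c1` differs from compound 3 in one place: methoxy in place of methyl on an aromatic carbon. Within the data shown here, none of the measured steps exchanges methyl for methoxy, so the precedent is only indirect. The step of a 1.2-fold higher number from compound 1 to compound 3 (0.08 log units; within the scatter) shows that methyl and chloro give numbers within the scatter of one another at this position, whereas a 4.2-fold higher number from compound 1 to compound 2 (0.62 log units; beyond the scatter) and a 3.5-fold lower number from compound 2 to compound 3 (0.54 log units; beyond the scatter) show that bromo costs a modest amount in this assay. A substituent other than chloro or methyl has so far brought a modest rise, and the same is expected here, though a result within the scatter cannot be excluded. Compound 4 is therefore estimated at 11 nM, within 4 nM to 30 nM. The expected step is a 1.8-fold higher number from compound 3 to compound 4 (0.26 log units; within the scatter).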

Compound 4, half-maximal inhibitory concentration: 8 nM
Estimate against measurement, compound 4: 1.4-fold (0.14 log units) above; low and high end bracket the measured number.
By their numbers in this assay, from the lowest: compounds 1, 3 and 4 (each within the scatter of the next); then compound 2.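

In this assay, methoxy, which brings one more heavy atom than methyl and one hydrogen-bond acceptor, stays within the scatter of both methyl (a 1.3-fold higher number from compound 3 to compound 4 (0.12 log units; within the scatter)) and chloro (a 1.6-fold higher number from compound 1 to compound 4 (0.20 log units; within the scatter)) at this position. Bromo remains the one group set apart (a 2.6-fold lower number from compound 2 to compound 4 (0.42 log units; beyond the scatter)), as its steps to all three other groups lie beyond the scatter. No measurement at hand explains why these groups fall as they do.

As far as these compounds go, whether an amine, a carboxylic acid or a longer chain such as ethoxy at this position would stay with chloro, methyl and methoxy or move as far as bromo remains open. The four compounds share the rest of their structure, so they say nothing about changes elsewhere on the shared core.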